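The source may report more compounds than this note shows. Statements on the series, on what has been measured and on what is new or still open speak of the compounds shown alone.

In a functional assay on cells for antagonist activity at Glucagon receptor (Homo sapiens), read by cAMP accumulation, in the presence of a further agent that is not named here (a lower number here means a stronger inhibitor, a higher number a weaker inhibitor), compound 1 `O=C(O)CCNC(=O)c1ccc(C(Oc2ccc(-n3cc(C(F)(F)F)cn3)cc2)C2CC2)cc1` gives 15000 nM, and compound 3 `O=C(O)CCNC(=O)c1ccc(C(Oc2ccc(-n3cc(C(F)(F)F)cn3)cc2)C2CCC2)cc1` gives 3000 nM. For the measured compounds named here, the only measured change between neighbours is a 5.0-fold lower number from compound 1 to compound 3 (0.70 log units; beyond the scatter). Compound 2 `CCCC(Oc1ccc(-n2cc(C(=O)N(C)C)cn2)cc1)c1ccc(C(=O)NCCC(=O)O)cc1` gives > 30000 nM, which is a limit of the assay and not a number. Compound 2 therefore stands at the limit of > 30000 nM in this assay, at which 1 of the 3 values shown sits, so its true weakness is not pinned down. Compound 4 `CCCC(Oc1ccc(-n2cc3c(n2)CCCC3)cc1)c1ccc(C(=O)NCCC(=O)O)cc1` differs from compound 2 in one place: a group of 9 heavy atoms (7 carbon, 2 nitrogen; one five-membered aromatic ring with 2 hetero atoms, one six-membered non-aromatic ring of carbon only) in place of a group of 10 heavy atoms (6 carbon, 3 nitrogen, 1 oxygen; one five-membered aromatic ring with 2 hetero atoms), on an aromatic carbon. Going by the values given here, no measured step bears on this exchange, since the step from compound 1 to compound 3 alters the small ring on the saturated carbon and leaves the group on the aromatic carbon untouched. Compound 4 is therefore expected near 15000 nM, between 4000 nM and 50000 nM. As an expectation, that amounts to an at least 2.0-fold lower number from compound 2 to compound 4 (0.30 log units; that floor lies within the scatter).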

Compound 4, antagonist equilibrium constant: 4200 nM
Compound 4: middle estimate off by 3.6-fold (0.55 log units), on the high side; measured number inside the range.
By their numbers in this assay, from the lowest: compounds 3 and 4 (each within the scatter of the next); then compound 1. At a limit, above all of these: compound 2.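

In this assay, for the compounds shown here, this is the first measured sign that the group on the aromatic carbon matters, not only the small ring on the saturated carbon. Replacing 4-(dimethylcarbamoyl)-1H-pyrazol-1-yl with the group that adds a six-membered non-aromatic ring of carbon only gives an at least 7.1-fold lower number from compound 2 to compound 4 (0.85 log units; beyond the scatter). The true size of this step stays unknown, as compound 2 has a limit of the assay and not a number: the limit of > 30000 nM in this assay, at which 1 of the 4 values shown sits.

From the compounds shown here alone, it remains open whether a nitrile or an amine on that aromatic carbon would give a lower number still. Going by these compounds, it also remains open whether the step would hold with cyclobutyl on the saturated carbon.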